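The compounds below may be only part of what the source reports. "The series", "measured", "known", "first", "only" and "open" are said of these compounds alone.

Four compounds built on a shared core are compared here, and three of them have been tested in a functional assay on HT-29 cells (Homo sapiens) for cytotoxicity, read by MTT assay, with a stated time of 72 h; a lower number here means a stronger inhibitor, a higher number a weaker inhibitor. Compound 1 `COc1cc2c(Oc3ccc(NC(=O)c4nnn(-c5ccccc5)c4C)cc3F)ccnc2cc1OCCCN1CCCC1` gives 130 nM in this assay. Compound 3 `COc1cc2c(Oc3ccc(NC(=O)c4nnn(-c5ccccc5)c4C)cc3F)ccnc2cc1OCCCN1CCCCC1` differs from compound 1 by one change, (piperidin-1-yl in place of pyrrolidin-1-yl on a saturated chain carbon, three bonds along the chain from an oxygen on an aromatic ring), and in this assay compound 3 gives 120 nM. That change made a step of a 1.1-fold lower number from compound 1 to compound 3 (0.03 log units; within the scatter).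

Compound 2 `COc1cc2c(Oc3ccc(NC(=O)c4nnn(-c5ccc(F)cc5)c4C(F)(F)F)cc3F)ccnc2cc1OCCCN1CCCC1` carries a core that differs from that of compound 1 in more than one place, so the difference between the two cores is not broken down here. In this assay compound 2 gives 120 nM, which at the digits recorded is level with compound 3 and separated from compound 1 by an amount that falls within the ordinary spread of repeated measurements.

Compound 4 `COc1cc2c(Oc3ccc(NC(=O)c4nnn(-c5ccc(F)cc5)c4C(F)(F)F)cc3F)ccnc2cc1OCCCN1CCCCC1` has not yet been measured. It stands to compound 2 exactly as compound 3 stands to compound 1: the change is piperidin-1-yl in place of pyrrolidin-1-yl on a saturated chain carbon, three bonds along the chain from an oxygen on an aromatic ring, the same change at the same place. Because that same change gave only a 1.1-fold lower number from compound 1 to compound 3 (0.03 log units; within the scatter), the step from compound 2 to compound 4 is expected to be small as well, about a 1.0-fold lower number from compound 2 to compound 4 (0.02 log units; within the scatter). Starting from the value of compound 2 and applying a step of this size, compound 4 is estimated to give 115 nM in this assay, with a plausible range from 60 nM to 240 nM. This expectation rests on a single earlier instance of the change, so it carries the uncertainty of that one comparison.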

Compound 4, half-maximal inhibitory concentration: 150 nM
Estimate against measurement, compound 4: 1.3-fold (0.12 log units) below, and the stated range covers the measured number.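

In this assay, putting piperidin-1-yl in place of pyrrolidin-1-yl on the core of compound 2 gives a 1.3-fold higher number from compound 2 to compound 4 (0.10 log units; within the scatter), a step too small to be told apart from the ordinary spread of repeated measurements. Set beside the earlier instance, the two steps agree within that spread, so on these two cores the swap carries over as a step that cannot be distinguished from no effect at all: the same change on two cores in this assay, a 1.1-fold lower number (0.03 log units; within the scatter) from compound 1 to compound 3 and a 1.3-fold higher number (0.10 log units; within the scatter) from compound 2 to compound 4, 1.4-fold (0.13 log units) apart, within the scatter of two such steps. This does not show that the two rings are interchangeable in general: it rests on just two pairs of compounds and one cell assay, and it says nothing about why the values sit where they do.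

The compounds shown leave open whether the same quiet result would hold for other amines at the end of the chain, such as morpholin-4-yl or dimethylamino, or for a longer chain than 3-(pyrrolidin-1-yl)propyl. They also leave open whether the swap stays this small on a core with a different group in place of the trifluoromethyl or methyl, and in this assay alone nothing can be said of its effect in any other assay.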